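A few compounds are considered here, and "the series" means these few. Any claim that something is new, unique, unknown or untested is made for them only; others in the source may bear on it.

Measured compounds:
- compound 2 `Cc1nn(C)cc1Nc1nc(N)c2c(C#N)c(N3CCC[C@H]3C)n(C)c2n1`: 38 nM
- compound 1 `Cc1nn(CC2(O)COC2)cc1Nc1nc(N)c2c(C#N)c(N3CCC[C@H]3C)n(C)c2n1`: 57 nM
- compound 3 `Cn1c(N2CCCC2)c(C#N)c2c(N)ncnc21`: 1480 nM

In an assay on isolated protein for inhibition of Leucine-rich repeat serine/threonine-protein kinase 2 (Homo sapiens), read by TR-FRET and LanthaScreen, with stated times of 50 min and 30 min, in the presence of a further agent that is not named here (on this read-out higher numbers stand for weaker inhibition and lower numbers for stronger inhibition), compound 2 gives the lowest of the three numbers. Compound 1 stands nearest to it, and the step of a 1.5-fold lower number from compound 1 to compound 2 (0.18 log units; within the scatter) is within the scatter, so the two cannot be ordered. Compound 3, which lacks the whole substituted amine group attached to the shared core, gives 1480 nM, a number far beyond the scatter from compound 2.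

Compound 4 `Cc1c(Nc2nc(N)c3c(C#N)c(N4CCC[C@H]4C)n(C)c3n2)cnn1C1COC1` has not yet been measured. It differs from compound 2 in one place: 5-methyl-1-(oxetan-3-yl)-1H-pyrazol-4-yl in place of 1,3-dimethyl-1H-pyrazol-4-yl on a nitrogen on an aromatic ring. For the measured compounds named here, only the step from compound 1 to compound 2 bears on this change, since it concerns the group on the same nitrogen; that step was small and within the scatter. Going by the values given here, nothing among the measured compounds speaks to the shift of the methyl within the five-membered aromatic ring, so that part of the change carries no evidence either way.

On this basis the expected step in this assay for compound 4 is a 1.6-fold higher number from compound 2 to compound 4 (0.20 log units; within the scatter), with a wide range to allow for the uncovered part of the change. The estimate for compound 4 is 60 nM, between 20 nM and 200 nM.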

Compound 4, half-maximal inhibitory concentration: 47 nM
Estimate against measurement, compound 4: 1.3-fold (0.11 log units) above; measured number inside the range.
By their numbers in this assay, from the lowest: compounds 2, 4 and 1 (each within the scatter of the next); then compound 3.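

In this assay, replacing 1,3-dimethyl-1H-pyrazol-4-yl with 5-methyl-1-(oxetan-3-yl)-1H-pyrazol-4-yl on a nitrogen on an aromatic ring gives a 1.2-fold higher number from compound 2 to compound 4 (0.09 log units; within the scatter), so a four-membered non-aromatic ring with a hetero atom can enter this place with no step beyond the scatter. The earlier compounds shown here showed only the change on a saturated chain carbon bound to an aromatic nitrogen, a 1.5-fold lower number from compound 1 to compound 2 (0.18 log units; within the scatter); the new step extends this small result to a change that also moves the methyl on the five-membered aromatic ring. No measurement on hand offers an explanation for why either step stays so small.

The methyl shift and the arrival of the oxetan-3-yl occur together in this one step, so the compounds shown cannot separate their contributions, and two opposing contributions cannot be told from two negligible ones. Also open, as far as these compounds go, is whether this place stays as tolerant of a different kind of group, such as a longer chain ending in an amine or a carboxylic acid in place of the oxetan-3-yl.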